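The source may report more compounds than this note shows. Statements on the series, on what has been measured and on what is new or still open speak of the compounds shown alone.

In a functional assay on HeLa S3 cells (Homo sapiens) for cytotoxicity, read by XTT assay, with a stated time of 6 days (on this read-out higher numbers stand for weaker inhibition and lower numbers for stronger inhibition), compound 1 `CN(C)c1ncnc2[nH]cc(Sc3cccs3)c12` gives > 25000 nM, which is a limit of the assay and not a number. Compound 2 `Cc1ncnc2[nH]cc(Sc3cccs3)c12` gives > 25000 nM, which is also a limit, so compound 2 has no exact value. Compound 3 `COc1ncnc2[nH]cc(Sc3cccs3)c12` carries methoxy in place of methyl on an aromatic carbon. For the measured compounds named here, the only measured step bearing on this is a step that the two limits leave unreadable from compound 1 to compound 2, and it has no readable size. Because of the limit of > 25000 nM in this assay, at which 2 of the 2 values shown sit, no step beyond the scatter is expected in this assay. The expected step is a step that the limit leaves unreadable from compound 2 to compound 3. For compound 3, the estimated value is 28000 nM, with an expected range from 12000 nM to 50000 nM.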

Compound 3, half-maximal inhibitory concentration: 23900 nM
The estimate for compound 3 lay 1.2-fold (0.07 log units) above the measured number, within the range that was stated.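

In this assay, for the compounds shown here, compound 3 gives 23900 nM, the first exact number for any group at this position on the shared core. Methoxy in place of methyl gives an at least 1.0-fold lower number from compound 2 to compound 3 (0.01 log units; that floor lies within the scatter), and methoxy in place of dimethylamino gives an at least 1.0-fold lower number from compound 1 to compound 3 (0.01 log units; that floor lies within the scatter), so neither step can be said to go beyond the scatter. How far the other two compounds really lie from compound 3 stays hidden because of this: the limit of > 25000 nM in this assay, at which 2 of the 3 values shown sit.

Still open, on these data alone, is whether any group at this position can bring the number clearly down. A primary amine, a carboxylic acid or a longer alkoxy chain might answer that.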